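From furan-2-yl to a larger group, at the limit

A few compounds are considered here, and "the series" means these few. Any claim that something is new, unique, unknown or untested is made for them only; others in the source may bear on it.

In an ADME assay on Vero cells (Chlorocebus sabaeus) for cytotoxicity, read by MTT assay, with a stated time of 48 h (a higher number here means a weaker inhibitor, a lower number a stronger inhibitor), compound 1 (`O=C(OC1CCC(CN2CCN(c3cc(=O)c4cc(C(F)(F)F)cc([N+](=O)[O-])c4s3)CC2)CC1)c1cccc(C(F)(F)F)c1`) reads > 64 ug/mL as a limit of the assay. Compound 2 (`CC(C)S(=O)(=O)OC1CCC(CN2CCN(c3cc(=O)c4cc(C(F)(F)F)cc([N+](=O)[O-])c4s3)CC2)CC1`) reads > 64 ug/mL as a limit too. Compound 3 (`O=C(OC1CCC(CN2CCN(c3cc(=O)c4cc(C(F)(F)F)cc([N+](=O)[O-])c4s3)CC2)CC1)c1ccco1`) also reads > 64 ug/mL as a limit and so carries no number of its own.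

Compound 4 (`O=C(OC1CCC(CN2CCN(c3cc(=O)c4cc(C(F)(F)F)cc([N+](=O)[O-])c4s3)CC2)CC1)c1ccc2c(c1)OCC2`) differs from compound 3 on a carbonyl carbon (a group of 9 heavy atoms (8 carbon, 1 oxygen; one five-membered non-aromatic ring with 1 hetero atom, one six-membered aromatic ring of carbon only) in place of a group of 5 heavy atoms (4 carbon, 1 oxygen; one five-membered aromatic ring with 1 hetero atom), on a carbonyl carbon) and nowhere else. The closest measured change is the one on that same carbonyl carbon (a step that the two limits leave unreadable from compound 1 to compound 3) while the changes on the oxygen (a step that the two limits leave unreadable from compound 1 to compound 2) and (a step that the two limits leave unreadable from compound 2 to compound 3) lie further off. None of these has a readable size.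

Because the limit of > 64 ug/mL in this assay, at which 3 of the 3 values shown sit, takes in compound 3 as well, no step beyond the scatter and no direction is expected in this assay for the larger group. The expected change is small (a number no higher from compound 3 to compound 4 (the limit leaves the size open)) and another limit is the likeliest reading. Compound 4 is estimated at 64 ug/mL within an expected range of 32 ug/mL to 128 ug/mL if a number is reported at all.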

Compound 4, half-maximal inhibitory concentration: > 64 ug/mL
Compound 4: no number, only a limit (the forecaster's own chance of this, stated with the estimate: 85%); the middle value lies on the limit itself.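

In this assay, for the compounds shown here, compound 4 gives > 64 ug/mL, a limit of the assay, so no step between it and compound 1, compound 2 or compound 3 can be read. The compounds shown leave open whether any change on the carbonyl carbon or the oxygen alters the reading at all, as all of them share one limit: the limit of > 64 ug/mL in this assay, at which 4 of the 4 values shown sit.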